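The compounds below may be only part of what the source reports. "The series", "measured", "known", "first", "only" and "open" are said of these compounds alone.

Measured in a functional assay on the whole organism for inhibition, with Mus musculus as the target; a higher number here means that more compound is needed for the effect, a lower number that less compound is needed:
- compound 1 `CN1Cc2c(N)cccc2C(c2ccc(F)cc2)C1`: 0.25 mg/kg
- compound 2 `CC(C)c1ccc(C2CN(C)Cc3c(N)cccc32)cc1`: 68 mg/kg
- compound 3 `CCCNC(=O)Nc1cccc2c1CN(C)CC2c1ccccc1`: > 80 mg/kg (a limit, not a number)

For compound 3 the reading is only a limit: the limit of > 80 mg/kg in this assay, at which 1 of the 3 values shown sits. Compound 4 `CN1Cc2c(NC(=O)CN3CCCC3)cccc2C(c2ccccc2)C1` differs from it by (pyrrolidin-1-yl)methyl in place of propylamino on a carbonyl carbon. Within the data shown here, no measured step covers this change. Among the measured compounds shown here, the one measured step, a 270-fold higher number from compound 1 to compound 2 (2.43 log units; beyond the scatter), is isopropyl in place of fluoro on an aromatic carbon. It shows that a single change can move this assay strongly, but gives no direction here. A modest drop is therefore expected, an at least 1.4-fold lower number from compound 3 to compound 4 (0.16 log units; that floor lies within the scatter), with the result possibly staying at the limit. The estimate for compound 4 is 55 mg/kg, within a range of 15 mg/kg to 200 mg/kg.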

Compound 4, dose for half-maximal effect: about 25 mg/kg
Beside the measured number, compound 4's estimate is 2.2-fold (0.34 log units) above it, and the stated range covers the measured number.
By their numbers in this assay, from the lowest: compound 1; then compound 4; then compound 2. At a limit, above all of these: compound 3.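

In this assay, (pyrrolidin-1-yl)methyl in place of propylamino on this carbonyl carbon gives an at least 3.2-fold lower number from compound 3 to compound 4 (0.50 log units; beyond the scatter). Among these compounds, this is the first sign that a change at this acylated amino position, and not only one on an aromatic carbon, can move the dose needed. The true size of the step remains unknown, as compound 3 gives only a limit, not a number: the limit of > 80 mg/kg in this assay, at which 1 of the 4 values shown sits.

The compounds shown leave open whether the ring itself matters. A piperidine ring or an open-chain dimethylamino group at the same place could give a similar or quite different dose.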